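The source may report more compounds than this note shows. Statements on the series, on what has been measured and on what is new or still open speak of the compounds shown alone.

The measured compounds:

Compound 1, `O=C1CSC(c2ccc([N+](=O)[O-])cc2)N1C(=O)Nc1ccncc1`, in an ADME assay on TZM cells (Homo sapiens) for cytotoxicity, read by MTT assay, with a stated time of 48 h (on this read-out lower numbers stand for higher toxicity in this test and higher numbers for lower toxicity in this test), gives 58600 nM.
Compound 2, `Cc1ccc(NS(=O)(=O)N2C(=O)CSC2c2c(F)cccc2Cl)cc1`, in this assay gives 136000 nM.
Compound 3, `N#Cc1ccc(N2C(=O)CSC2c2c(Cl)cccc2Cl)nc1`, in this assay gives 60000 nM.

Among these three, compound 2 stands with the highest number in this assay. Its nearest neighbour is compound 3, whose number lies lower by a margin beyond the usual scatter of this measurement, and compound 1 lies lower still by a margin also beyond the scatter. No pair of these compounds differs in only one place, so no single structural change can be tied to a measured step.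

The unmeasured compound 4, `Cc1ccc(NS(=O)(=O)N2C(=O)CSC2c2c(Cl)cccc2Cl)cc1`, differs from compound 2 as follows: chloro in place of fluoro on an aromatic carbon. The two compounds share everything else. Within the data shown here, no measured pair shows what this change does to the half-maximal cytotoxic concentration in this assay, so the expectation rests on the change being a swap of one halogen for another on the same aromatic carbon.

Compound 4 is therefore expected to remain close to compound 2, with a step of a 1.2-fold lower number from compound 2 to compound 4 (0.09 log units; within the scatter) that is not expected to exceed the scatter. The estimate for compound 4 in this assay is 110000 nM, within a range from 50000 nM to 250000 nM.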

Compound 4, half-maximal cytotoxic concentration: 75700 nM
Compound 4: middle estimate off by 1.5-fold (0.16 log units), on the high side; low and high end bracket the measured number.
By their numbers in this assay, from the lowest: compounds 1, 3, 4 and 2 (each within the scatter of the next, the first and the last beyond it).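

Chloro in place of fluoro on an aromatic carbon, ortho to a large group, is the first change in this set that can be read on its own, and in this assay it amounts to a 1.8-fold lower number from compound 2 to compound 4 (0.25 log units; within the scatter) with everything else held the same. Going from 2-chloro-6-fluorophenyl to 2,6-dichlorophenyl therefore does not separate the two compounds beyond repeat measurement, so at this position the half-maximal cytotoxic concentration does not register this exchange of one halogen for the other, though that rests on a single pair. Nothing at hand says what lies behind the size of this step.

On these data alone, whether a group other than a halogen on this aromatic carbon, such as a methoxy group, an amine or a carboxylic acid, would give a step beyond the scatter remains open. Also open, as far as these compounds go, is whether the same exchange of fluoro for chloro would give a similar step on the core of compound 3, or whether it holds only for the core shared by compound 2 and compound 4.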